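One Drawn Stereocentre, Then the Same Compound Without It

The compounds below may be only part of what the source reports. "The series", "measured", "known", "first", "only" and "open" are said of these compounds alone.

Of the compounds shown here, three sharing one core have been measured in an assay on mitochondria (strain Sprague-Dawley) for inhibition of Amine oxidase [flavin-containing] B (Rattus norvegicus), read by spectrophotometry; on this read-out lower numbers stand for stronger inhibition and higher numbers for weaker inhibition. Compound 1, `Cc1c(C)c2ccc(CCc3ccccc3)cc2oc1=O`, gives 457 nM. Compound 2, `Cc1c(C)c2ccc(Oc3ccccc3)cc2oc1=O`, gives 3240 nM. Compound 3, `Cc1c(C)c2ccc(OC[C@@H](O)c3ccccc3)cc2oc1=O`, gives 28.2 nM, the lowest of the three numbers, and therefore the strongest inhibitor among them. Its gap to compound 1 and its larger gap to compound 2 both lie beyond the usual scatter of this assay, so its position at the head of the set is not in doubt.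

Compound 4 is `Cc1c(C)c2ccc(OCC(O)c3ccccc3)cc2oc1=O`. Its difference from compound 3 is the two compounds have the same atoms and bonds; at least one stereo element is drawn with a configuration in one of them and without one in the other: 1 of 1 stereo elements differ; a stereocentre at a saturated chain carbon is drawn S in compound 3 and without a configuration in compound 4. In plain terms, the same material is described, but the drawing of compound 4 no longer specifies which of the two mirror-image forms is meant, so it may stand for a mixture of both. If the form drawn for compound 3 carries most of the activity, a mixture would be expected to read somewhat weaker, with the other form contributing little or nothing. Such a shift would be expected to stay within, or only just past, the scatter of this assay, and the expected step from compound 3 to compound 4 is a 1.8-fold higher number from compound 3 to compound 4 (0.25 log units; within the scatter). The expected value for compound 4 in this assay is therefore 50 nM, with a range from 20 nM to 160 nM.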

Compound 4, half-maximal inhibitory concentration: 70.8 nM
Compound 4: the middle estimate sits 1.4-fold (0.15 log units) below what was measured; low and high end bracket the measured number.
By their numbers in this assay, from the lowest: compound 3; then compound 4; then compound 1; then compound 2.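

In this assay the set now holds its first step that can be read at a single place: a 2.5-fold higher number from compound 3 to compound 4 (0.40 log units; beyond the scatter). The step is modest, yet it lies beyond the usual scatter. Among the compounds shown here, since atoms and bonds stay the same, it concerns only the stereocentre at the saturated chain carbon, and it shows that the compound drawn S at this carbon gives a lower number than the compound drawn without a configuration, something the earlier compounds, which differ from one another in more than one place, could not show. The structures offer only one difference to which this step can be traced: the fact that one of compounds 3 and 4 is drawn with a defined configuration and the other without, at the place where they differ

How much each mirror-image form contributes stays open, as the compounds shown include neither the form with the opposite configuration at this carbon nor any statement of what proportion of each form compound 4 contains. Also open, on these data alone, is how much the hydroxyl on this chain itself matters, a question that a compound with an amine or a methoxy group in its place could address.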